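This account rests on a few compounds, and the source may have more. Where it says the series, first, only, none or still open, it means among the compounds named here.

Measured so far:
compound 1, `Cc1ccc(/N=N/N(C)C(=O)CCc2ccc(O)cc2)cc1`, gives 8.7 h in an ADME assay on a cell-free system (plasma, Homo sapiens) for metabolic stability, read by HPLC; a higher number here means that the compound lasts longer, a lower number that the compound disappears faster;
compound 2, `Cc1ccc(/N=N/N(C)C(=O)NCCSc2ccc(O)cc2)cc1`, gives 88.5 h in this assay;
compound 3, `CN(/N=N/c1ccc(Br)cc1)C(=O)CCc1ccc(O)cc1`, gives 8.3 h in this assay.

Compound 3 arises from compound 1 by one change, (bromo in place of methyl on an aromatic carbon). The step it made in this assay was a 1.0-fold lower number from compound 1 to compound 3 (0.02 log units; within the scatter), so the two compounds cannot be told apart on this read-out. Compound 2 stands well apart from both: its number is the highest of the three, and its two neighbours lie beyond the scatter. How the core of compound 2 differs from the core of compound 1 is not broken down here.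

Compound 4, `CN(/N=N/c1ccc(Br)cc1)C(=O)NCCSc1ccc(O)cc1`, has not yet been measured. It arises from compound 2 by the same change, (bromo in place of methyl on an aromatic carbon). Because a 1.0-fold lower number from compound 1 to compound 3 (0.02 log units; within the scatter) left the half-life essentially unchanged, the step from compound 2 to compound 4 in this assay is expected to be a 1.0-fold lower number from compound 2 to compound 4 (0.02 log units; within the scatter). This expectation rests on a single pair, compound 1 and compound 3, and so is tentative. Compound 4 is therefore expected to give about 85 h, with a likely range from 45 h to 170 h.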

Compound 4, half-life in the Homo sapiens assay: 105 h
For compound 4 the middle estimate is 1.2-fold (0.09 log units) below the measured one; low and high end bracket the measured number.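

In the Homo sapiens assay compound 4 gives 105 h. In the Homo sapiens assay the swap of 4-methylphenyl to 4-bromophenyl on the second core gives a 1.2-fold higher number from compound 2 to compound 4 (0.07 log units; within the scatter) and so, like the first step, it is too small to separate the two compounds. Carried from one core to the other, the change behaves the same way on both, even though the two cores sit far apart in half-life: the same change on two cores in the Homo sapiens assay, a 1.0-fold lower number (0.02 log units; within the scatter) from compound 1 to compound 3 and a 1.2-fold higher number (0.07 log units; within the scatter) from compound 2 to compound 4, 1.2-fold (0.09 log units) apart, within the scatter of two such steps. Within the data shown here, this rests on only two pairs, so it shows that the swap can be carried across these two cores, not that it would be silent on every core. In a physicochemical assay for lipophilicity, read by HPLC, in phosphate buffer, measured as octanol-water partition, with a stated time of 30 min (on this read-out lower numbers stand for lower lipophilicity and higher numbers for higher lipophilicity), compound 2 gives 4.21 and compound 4 gives 3.95. Among these compounds, in the physicochemical assay the single step available, a number 0.26 log units lower from compound 2 to compound 4 (within the scatter), has no second pair to be compared with.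

The compounds shown carry only methyl or bromo at this place, so it stays open whether chloro, methoxy or a carboxylic acid there would also leave the half-life where it is. On these data alone, it also stays open whether the swap would hold on a core with a longer chain.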